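Diaryl urea series: notes toward compound 4

A few compounds are considered here, and "the series" means these few. Any claim that something is new, unique, unknown or untested is made for them only; others in the source may bear on it.

Measured so far in a functional assay on RXF 393 cells (Homo sapiens) for inhibition, read by sulforhodamine B assay, with a stated time of 48 h, tested at 1 uM; on this read-out lower numbers stand for a stronger effect and higher numbers for a weaker effect at the one concentration tested:
- compound 1 `COc1cc(Cl)cc(-c2nn(-c3cccc(NC(=O)Nc4ccc(Cl)c(C(F)(F)F)c4)c3)cc2-c2ccncc2)c1`: 78%
- compound 2 `COc1cc(Cl)cc(-c2nn(-c3cccc(NC(=O)Nc4cc(C(F)(F)F)cc(C(F)(F)F)c4)c3)cc2-c2ccncc2)c1`: 50%
- compound 3 `COc1cc(Cl)cc(-c2nn(-c3cccc(NC(=O)Nc4ccc(Cl)c(Cl)c4)c3)cc2-c2ccncc2)c1`: 75%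

Compound 3 stands second highest of the three numbers. Its nearest neighbour is compound 1, which lies a few points higher, and the step of a number 3 percentage points lower from compound 1 to compound 3 (within the scatter) is within the scatter, so the two read as the same. Among the measured compounds shown here, compound 2 lies clearly apart, its number beyond the scatter lower than that of compound 3, and for that pair no single-place step is given; only the two values themselves are known.

Compound 4 `COc1cc(Cl)cc(-c2nn(-c3cccc(NC(=O)Nc4cccc(C(F)(F)F)c4)c3)cc2-c2ccncc2)c1` is the next entry. Its change from compound 3 is 3-(trifluoromethyl)phenyl in place of 3,4-dichlorophenyl on an amide-type nitrogen. For the measured compounds named here, no measured step covers this exact exchange. Going by the values given here, the one step that bears on the urea aryl end, from compound 1 to compound 3, shows that swapping chloro and trifluoromethyl on that ring moved the number by no more than the scatter. On that basis the expected step of a number 3 percentage points higher from compound 3 to compound 4 (within the scatter) is taken as none beyond the scatter, with no direction claimed. Compound 4 is therefore estimated at 78%, with a range from 62% to 92% in this assay.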

Compound 4, a percentage reported as activity, at one concentration (the size of the read-out at that concentration, not a potency): 68%
Compound 4: the middle estimate sits 10 percentage points above what was measured, and the stated range covers the measured number.
By their numbers in this assay, from the lowest: compound 2; then compounds 4, 3 and 1 (each within the scatter of the next).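

In this assay, the exchange of 3,4-dichlorophenyl for 3-(trifluoromethyl)phenyl on the amide-type nitrogen gives a number 7 percentage points lower from compound 3 to compound 4 (within the scatter), and hydrogen in place of chloro on the urea aryl ring gives a number 10 percentage points lower from compound 1 to compound 4 (within the scatter), so the chloro carried by compound 1 and compound 3 has no effect here that can be told from the scatter. Hydrogen in place of trifluoromethyl gives a number 18 percentage points higher from compound 2 to compound 4 (beyond the scatter), the only single-place step on this ring that lies beyond the scatter, and it ties the separation of compound 2 to the trifluoromethyl that compound 4 lacks. No measurement is at hand that would explain any of these steps.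

The compounds shown carry only chloro and trifluoromethyl on this ring, so it remains open whether a nitrile, a methoxy or an amine in place of that trifluoromethyl would hold the number of compound 2 at 50%. The shared core is also constant throughout, which leaves open whether the same step would appear with a carboxylic acid in place of the methoxy on the core.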